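Fluoro Replaces Methoxy on a Weakly Binding Core

The source may report more compounds than this note shows. Statements on the series, on what has been measured and on what is new or still open speak of the compounds shown alone.

Compound 2 `COc1ccc2c(c1)C(C(C)c1ccccn1)=C(CCN(C)C)C2` gives 8910 nM in an assay on CHO-K1 cells for binding affinity to muscarinic acetylcholine receptor M5 (Homo sapiens) (a lower number here means a stronger inhibitor, a higher number a weaker inhibitor), the highest of the two numbers recorded so far. Its nearest neighbour, compound 1 `Cc1ccc2c(c1)C(C(C)c1ccccn1)=C(CCN(C)C)C2`, gives 5890 nM in this assay, and the step of a 1.5-fold higher number from compound 1 to compound 2 (0.18 log units; within the scatter) stays within the scatter. Compound 3 `CC(C1=C(CCN(C)C)Cc2ccc(F)cc21)c1ccccn1` has not yet been measured in this assay. It differs from compound 2 in one place: fluoro in place of methoxy on an aromatic carbon. Among the measured compounds shown here, the single measured step also exchanged the group on this same aromatic carbon and moved the number by less than the scatter, so it bears on the present change only loosely; no measured pair shows fluoro in place of methoxy directly. On that basis a step of no more than the scatter is expected, a 1.3-fold lower number from compound 2 to compound 3 (0.10 log units; within the scatter). Compound 3 is therefore estimated at 7000 nM in this assay, with a range from 3000 nM to 16000 nM.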

Compound 3, inhibition constant: 1050 nM
Beside the measured number, compound 3's estimate is 6.7-fold (0.82 log units) above it; the measured number lies below the stated range.
By their numbers in this assay, from the lowest: compound 3; then compounds 1 and 2 (each within the scatter of the next).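

In this assay, the aromatic carbon that seemed indifferent when methoxy took the place of methyl now proves able to move the number: fluoro in place of methoxy gives an 8.5-fold lower number from compound 2 to compound 3 (0.93 log units; beyond the scatter), and fluoro in place of methyl gives a 5.6-fold lower number from compound 1 to compound 3 (0.75 log units; beyond the scatter). Of the three groups shown on this carbon, fluoro alone stands apart, while methyl and methoxy remain within the scatter of each other. Both steps are still modest, and compound 3, at 1050 nM, remains a weak binder on this scale.

Nothing available accounts for the separation of fluoro from the other two groups. The compounds shown leave open whether chloro, a nitrile or a plain hydrogen on this carbon would side with fluoro or with methyl and methoxy.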